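Aryl swap on the ethenyl chain of compound 1

The compounds below may be only part of what the source reports. "The series", "measured", "known", "first", "only" and "open" are said of these compounds alone.

Measured so far in a functional assay on PC-3 cells (Homo sapiens) for cytotoxicity, read by MTT assay, with a stated time of 72 h; on this read-out lower numbers stand for stronger inhibition and higher numbers for weaker inhibition
- compound 1 `O=C(/C=C/c1cccc(Cl)c1Cl)Nc1cc2c(Nc3ccc(F)c(Cl)c3)ncnc2cc1O[C@H]1CCOC1` (27500 nM)
- compound 2 `COc1ccc(/C=C/C(=O)Nc2cc3c(Nc4ccc(F)c(Cl)c4)ncnc3cc2OC)cc1` ("not active" (no number reported))
- compound 3 `COc1cc2ncnc(Nc3ccc(F)c(Cl)c3)c2cc1NC(=O)/C=C/c1ccccc1[N+](=O)[O-]` (14300 nM)

Compound 1 (27500 nM) and compound 3 (14300 nM) lie within the usual scatter of each other, and compound 2 gave no number. Compound 1 therefore stands level with the only other numeric entry in the series.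

Compound 4 `COc1ccc(OC)c(/C=C/C(=O)Nc2cc3c(Nc4ccc(F)c(Cl)c4)ncnc3cc2O[C@H]2CCOC2)c1` has not yet been measured. It differs from compound 1 in one place: 2,5-dimethoxyphenyl in place of 2,3-dichlorophenyl on a double-bonded chain carbon bound to a double-bonded chain carbon. Among the measured compounds shown here, no measured pair isolates this change, so the expectation is loose. Compound 2 also has a methoxy group on its phenyl ring and reads "not active" (no number reported) in this assay, so a result without a number remains possible for compound 4.

No step beyond the scatter is expected, and the estimated 1.1-fold higher number from compound 1 to compound 4 (0.04 log units; within the scatter) in this assay reflects that. The estimate for compound 4 is 30000 nM (expected range 12000 nM to 75000 nM).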

Compound 4, half-maximal inhibitory concentration: 8730 nM
For compound 4 the middle estimate is 3.4-fold (0.54 log units) above the measured one, and the stated range ends above it.
By their numbers in this assay, from the lowest: compounds 4, 3 and 1 (each within the scatter of the next, the first and the last beyond it).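

In this assay the series now holds a step at this place: a 3.2-fold lower number from compound 1 to compound 4 (0.50 log units; beyond the scatter). The aryl group on the ethenyl chain is therefore a position where a single change moves the read-out, here 2,5-dimethoxyphenyl in place of 2,3-dichlorophenyl. Compound 4 also shows that a phenyl ring carrying methoxy groups at this position can give a numeric result, and nothing measured here bears on why the number falls.

Both substituents on the ring differ at once, so the compounds shown do not separate the loss of the two chlorines from the gain of the two methoxy groups. As far as these compounds go, how a single methoxy group, or an amine or a carboxylic acid on this phenyl ring, would read in this assay remains open.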